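The compounds below may be only part of what the source reports. "The series", "measured", "known", "first", "only" and "open" are said of these compounds alone.

Notes on the series. The shared core is that of compound 1 `CCCOc1ccc(C(O)C2OC(=O)c3c(OC)cc(OC)cc32)cc1`, which carries a propoxy group. In an ADME assay on RAW264.7 cells (Mus musculus) for cytotoxicity, read by MTT assay, with a stated time of 24 h, in the presence of a further agent that is not named here (a lower number here means a stronger inhibitor, a higher number a weaker inhibitor), compound 1 gives > 40000 nM, and this is a limit of the assay rather than a number. Compound 2 `CCCCOc1ccc(C(O)C2OC(=O)c3c(OC)cc(OC)cc32)cc1` differs from it by methyl in place of hydrogen on a saturated chain carbon, three bonds along the chain from an oxygen on an aromatic ring. In this assay compound 2 gives > 40000 nM, again a limit. The step that the two limits leave unreadable from compound 1 to compound 2 therefore cannot be sized; both values rest at the limit of > 40000 nM in this assay, at which 2 of the 2 values shown sit. Compound 3 `COc1cc(OC)c2c(c1)C(C(O)c1ccc(OCc3ccc(C#N)cc3)cc1)OC2=O` has not yet been measured in this assay. It differs from compound 1 in one place: 4-cyanophenyl in place of ethyl on a saturated chain carbon bound to an oxygen on an aromatic ring. Among the compounds with values here, no measured step bears on this change, since the one step in hand is unreadable. The two limits do show that both measured compounds lie at the top of the window, so no shift beyond the scatter can be read out of them in either direction. The estimate for compound 3 is 50000 nM, within 15000 nM to 200000 nM, most probably reported once more only as a limit. This expectation corresponds to an estimated step that the limit leaves unreadable from compound 1 to compound 3.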

Compound 3, half-maximal inhibitory concentration: > 40000 nM
Compound 3: no number, only a limit (the forecaster's own chance of this, stated with the estimate: 70%); the middle value lies beyond the limit too.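

Compound 3 adds no readable step, and its steps from compound 1 and compound 2 cannot be sized, because all three compounds rest at one and the same limit of the assay: the limit of > 40000 nM in this assay, at which 3 of the 3 values shown sit.

The compounds shown leave open at what concentration any of the three would reach half-maximal inhibition in this assay, and whether propoxy to (4-cyanobenzyl)oxy shifts it at all.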